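Aryl amide variation on the shared core: next step

The source may hold more compounds than are shown below. What is called first, only, known or untested is meant among the compounds shown, and "the series" means these compounds.

Compound 2 `COc1cccc(C(=O)Nc2cccc(/C=C/C(=O)c3nc4ccccc4[nH]3)c2)c1` is one of two members measured in a functional assay on 143B cells (Homo sapiens) for antiproliferative activity, read by MTT assay, with a stated time of 48 h; on this read-out higher numbers stand for weaker inhibition and lower numbers for stronger inhibition; in this assay compound 2 gives 4610 nM. Among the measured compounds shown here, its only comparator is compound 1 `O=C(Nc1cccc(/C=C/C(=O)c2nc3ccccc3[nH]2)c1)c1cccc(Br)c1`, which gives 4620 nM; the two numbers lie within the scatter of each other, so neither stands apart. For the measured compounds named here, the one measured step, a 1.0-fold lower number from compound 1 to compound 2 (0.00 log units; within the scatter), is the only guide for this position. Compound 3 `O=C(Nc1cccc(/C=C/C(=O)c2nc3ccccc3[nH]2)c1)c1cc(Cl)cc(Cl)c1` arises from compound 2 by 3,5-dichlorophenyl in place of 3-methoxyphenyl on a carbonyl carbon. This is the same position on the aryl amide as in the measured step, where a halogen and a methoxy gave the same read-out, so an exchange back to halogens, now two, is expected to move this assay little if at all: the step of a 1.0-fold lower number from compound 2 to compound 3 (0.01 log units; within the scatter) is expected to stay within the scatter. Compound 3 is accordingly estimated at 4500 nM, with a range from 1500 nM to 14000 nM.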

Compound 3, half-maximal inhibitory concentration: 3660 nM
Beside the measured number, compound 3's estimate is 1.2-fold (0.09 log units) above it, within the range that was stated.
By their numbers in this assay, from the lowest: compounds 3, 2 and 1 (each within the scatter of the next).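

In this assay the 3,5-dichlorophenyl group on the carbonyl carbon reads alike with the 3-methoxyphenyl group (a 1.3-fold lower number from compound 2 to compound 3 (0.10 log units; within the scatter)) and with the 3-bromophenyl group (a 1.3-fold lower number from compound 1 to compound 3 (0.10 log units; within the scatter)). The earlier pair covered only one halogen against one methoxy; the series now shows that two chlorines on this ring also give no step beyond the scatter, so all three aryl amides stand together at this position. No measurement at hand accounts for this flat read-out.

Going by these compounds, all three compounds carry a substituted phenyl ring here, so it remains open whether an amine, a carboxylic acid or a longer alkyl chain on this carbonyl carbon would give a step beyond the scatter. Also open, on these data alone, is whether these three compounds would still read alike outside this assay.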